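This account rests on a few compounds, and the source may have more. Where it says the series, first, only, none or still open, it means among the compounds named here.

In a functional assay on NCI-H460 cells (Homo sapiens) for inhibition, with a stated time of 72 h (on this read-out higher numbers stand for weaker inhibition and lower numbers for stronger inhibition), compound 1 `COc1cc(C(=O)c2ccc3c(ccn3C)c2)cc(OC)c1OC` gives 14.1 nM. Compound 2 `COc1cc(C(=O)c2ccc3c(ccn3CC(=O)O)c2)cc(OC)c1OC` gives 530 nM, the higher of the two numbers, which makes it the weaker inhibitor of this pair. Going by the values given here, the one measured step is large: a 38-fold higher number from compound 1 to compound 2 (1.58 log units; beyond the scatter), with carboxy in place of hydrogen on a saturated chain carbon bound to an aromatic nitrogen.

Compound 3 `COc1cc(C(=O)c2ccc3c(ccn3CCC(=O)O)c2)cc(OC)c1OC` has not yet been measured. Its difference from compound 2 is carboxymethyl in place of carboxy on a saturated chain carbon bound to an aromatic nitrogen. In words, carboxymethyl stands in place of carboxy at that same place, which turns carboxymethyl into 2-carboxyethyl when the change is read one bond further out. Among the compounds with values here, the measured step bears on this only indirectly, since the carboxy end it brought in remains in compound 3, and no measurement yet shows what a longer chain does. The expectation therefore stays near compound 2 at 530 nM, with a wide margin for that gap in the data. The expected change is a 1.3-fold lower number from compound 2 to compound 3 (0.12 log units; within the scatter), so no step beyond the scatter is anticipated. For compound 3 the estimated value is 400 nM, with an expected range from 100 nM to 1500 nM.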

Compound 3, half-maximal inhibitory concentration: > 10000 nM
Compound 3: a limit, no number; the forecaster's own chance of this, stated with the estimate: 3%; middle value at least 25-fold (1.39 log units) away from the limit.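

Compound 3 gives a limit and not a number in this assay: the limit of > 10000 nM in this assay, at which 1 of the 3 values shown sits.

The earlier step showed only what bringing in the carboxy end does, whereas compound 3 keeps that end and changes carboxymethyl in place of carboxy, and the result is an at least 18-fold higher number from compound 2 to compound 3 (1.27 log units; beyond the scatter). This place on the chain is therefore sensitive not just to whether the carboxy end is present but also to how far out it sits, since the longer 2-carboxyethyl chain costs a large further loss of inhibition. Measured against the hydrogen-bearing reference, the change amounts to an at least 700-fold higher number from compound 1 to compound 3 (2.85 log units; beyond the scatter), so both changes at this place point the same way and compound 1 remains the strongest inhibitor of the three.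

These compounds do not separate the effect of chain length from that of the carboxylic acid, as a plain propyl chain with no acid end would be needed to show what length alone does. From the compounds shown here alone, it also remains open whether a methyl ester, an amide or an amine at the end of the same chain would behave like the carboxylic acid in this assay.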